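Swapping the Ether Cap of Compound 2 for Pyridin-2-yl

The source may hold more compounds than are shown below. What is called first, only, known or untested is meant among the compounds shown, and "the series" means these compounds.

Compound 1 `CC(C)CCn1ccc(-c2ccccc2)c(C#N)c1=O` is measured in a functional assay on CHO cells for positive allosteric modulation of metabotropic glutamate receptor 2 (Homo sapiens), read by scintillation counting and GTPgammaS binding, with a stated time of 30 min (on this read-out lower numbers stand for an effect already at smaller amounts and higher numbers for an effect only at larger amounts of compound), where compound 1 gives 8510 nM. Compound 2 `CC(C)CCn1ccc(-c2ccc(OCC3CC3)cc2)c(C#N)c1=O` gives 290 nM, and compound 3 `CC(C)CCn1ccc(-c2ccc(OCC3CC3)c(Cl)c2)c(C#N)c1=O` gives 110 nM. Among these three numbers compound 2 stands second highest, with compound 3 nearest to it and compound 1 furthest away. The two measured steps are a 29-fold lower number from compound 1 to compound 2 (1.47 log units; beyond the scatter) and a 2.6-fold lower number from compound 2 to compound 3 (0.42 log units; beyond the scatter). Compound 4 `CC(C)CCn1ccc(-c2ccc(Oc3ccccn3)cc2)c(C#N)c1=O` differs from compound 2 in one place: pyridin-2-yl in place of cyclopropylmethyl on an oxygen on an aromatic ring. Within the data shown here, neither measured step exchanges the group on this oxygen, so neither bears on it directly; the step from compound 1 to compound 2 shows only that an oxygen-linked group on that ring accounts for most of the gain seen so far, and compound 4 keeps such a group. Among the measured compounds shown here, with no step showing how one cap on the oxygen compares with another, the expectation for compound 4 is a change about the size of the scatter, in no clear direction, as a 1.4-fold higher number from compound 2 to compound 4 (0.14 log units; within the scatter). Compound 4 is therefore estimated at 400 nM, between 100 nM and 1500 nM.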

Compound 4, half-maximal effective concentration: 646 nM
Compound 4: the middle estimate sits 1.6-fold (0.21 log units) below what was measured; the measured number falls inside the stated range.
By their numbers in this assay, from the lowest: compound 3; then compound 2; then compound 4; then compound 1.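

In this assay, among these compounds, the group capping the oxygen turns out to matter: a 2.2-fold higher number from compound 2 to compound 4 (0.35 log units; beyond the scatter) is the first measured exchange of one cap for another, and it lies beyond the usual scatter. Even so, the aromatic pyridin-2-yl cap keeps much of the gain over the bare hydrogen, with a 13-fold lower number from compound 1 to compound 4 (1.12 log units; beyond the scatter) being large, like a 29-fold lower number from compound 1 to compound 2 (1.47 log units; beyond the scatter) for the cyclopropylmethoxy group. No measurement here explains why the two caps give different numbers.

Still open, on these data alone, is whether the difference follows from the aromatic ring itself or from its nitrogen, which a plain phenyl cap on the same oxygen would help to separate. Also open, as far as these compounds go, is whether adding chloro to compound 4 would lower the number as it did for compound 2.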